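The source may hold more compounds than are shown below. What is called first, only, known or untested is meant among the compounds shown, and "the series" means these compounds.

Measured compounds:
compound 1, `COCCOc1cc2ncnc(Nc3cccc(B(O)O)c3)c2cc1OCCOC` — > 1000 nM
compound 2, `COCCOc1cc2ncnc(Nc3ccc(B(O)O)cc3)c2cc1OC` — > 1000 nM

Both readings come from an assay on isolated protein for inhibition of vascular endothelial growth factor receptor 1 (Homo sapiens), read by ELISA, with a stated time of 20 min; a higher number here means a weaker inhibitor, a lower number a stronger inhibitor. Compound 2 gives > 1000 nM in this assay, which is a limit of the assay and not a number. Compound 1 gives > 1000 nM in this assay, likewise a limit. Among the measured compounds shown here, compound 2 therefore stands at the limit of > 1000 nM in this assay, at which 2 of the 2 values shown sit; nothing separates it from compound 1, and no measured step exists in this set.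

Compound 3, `COCCOc1cc2ncnc(Nc3ccc(B(O)O)cc3)c2cc1OCCOC`, differs from compound 2 by methoxymethyl in place of hydrogen on a saturated chain carbon bound to an oxygen on an aromatic ring. For the measured compounds named here, with no measured step to lean on, the expected change from compound 2 to compound 3 is a step that the limit leaves unreadable from compound 2 to compound 3, that is, no move in either direction that the scatter of the assay would resolve. Compound 3 is expected at 2000 nM in this assay, with a range of 700 nM to 8000 nM, and most probably it will again be reported only as a limit.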

Compound 3, half-maximal inhibitory concentration: > 1000 nM
Compound 3 gave a limit, no number; the forecaster's own chance of this, stated with the estimate: 75%; the middle value is on the limit's open side.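

In this assay compound 3 gives > 1000 nM, a limit of the assay and not a number. Among the compounds shown here, no step among compound 1, compound 2 and compound 3 can be read, and all three stand together: the limit of > 1000 nM in this assay, at which 3 of the 3 values shown sit.

Still open, on these data alone, is whether the methoxymethyl difference between compound 2 and compound 3 changes inhibition in this assay at all.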